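An amine linker where an oxygen linker stood

The compounds below may be only part of what the source reports. "The series", "measured", "known", "first", "only" and "open" are said of these compounds alone.

Compound 1, `Cc1cc(OC2CCCC2)nc(Nc2ccc(C#N)cc2)n1`, gives 1050 nM in an ADME assay on MT4 cells (Homo sapiens) for cytotoxicity, read by MTT assay; a lower number here means that less compound is tolerated, a higher number that more compound is tolerated.
Compound 2, `N#Cc1ccc(Nc2nccc(OC3CCCC3)n2)cc1`, gives only a limit, >= 339000 nM, in this assay.
Compound 3, `Cc1cnc(Nc2ccc(C#N)cc2)nc1OC1CCCC1`, gives 9990 nM in this assay.

Compound 2 therefore sits at the limit of >= 339000 nM in this assay, at which 1 of the 3 values shown sits, and no number beyond that limit is known for it. The two measured steps, an at least 320-fold higher number from compound 1 to compound 2 (2.50 log units; beyond the scatter) and an at least 33-fold lower number from compound 2 to compound 3 (1.53 log units; beyond the scatter), both exchange a methyl for a hydrogen and leave the linker to the ring untouched. Compound 4, `N#Cc1ccc(Nc2nccc(NC3CCCC3)n2)cc1`, differs from compound 2 by cyclopentylamino in place of cyclopentyloxy on an aromatic carbon. Among the compounds with values here, none of the measured steps bears on this exchange, so no step beyond the scatter is expected in this assay. Compound 4 is accordingly expected to give about 200000 nM, between 30000 nM and 400000 nM, which would amount to an at least 1.6-fold lower number from compound 2 to compound 4 (0.22 log units; that floor lies within the scatter).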

Compound 4, half-maximal cytotoxic concentration: 9130 nM
Estimate against measurement, compound 4: 22-fold (1.34 log units) above; measured number outside the range, below it.
By their numbers in this assay, from the lowest: compound 1; then compounds 4 and 3 (each within the scatter of the next). At a limit, above all of these: compound 2.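

The earlier steps shown here exchanged only a methyl and a hydrogen on the ring. This one shows that the linker atom on the aromatic carbon next to the ring nitrogen also shifts the result in this assay, with no methyl present: cyclopentylamino in place of cyclopentyloxy gives an at least 37-fold lower number from compound 2 to compound 4 (1.56 log units; beyond the scatter). That size is only a floor, since compound 2 stands at a limit: the limit of >= 339000 nM in this assay, at which 1 of the 4 values shown sits.

On these data alone, whether the exchange acts the same way with a ring methyl, as in compound 1 or compound 3, stays open. So does what cyclohexylamino or N-methylcyclopentylamino would give at this position.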